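Acetoxymethyl to carbamoyloxymethyl on the shared core

This account rests on a few compounds, and the source may have more. Where it says the series, first, only, none or still open, it means among the compounds named here.

Measured so far:
compound 1 `CCOCc1c(C)nc2c(OCc3ccccc3)cccn12` — 35%
compound 2 `CC(=O)OCc1c(C)nc2c(OCc3ccccc3)cccn12` — 87%

In a functional assay on the whole organism (stomach) for inhibition, with Canis familiaris (Canis lupus familiaris) as the target, at a dose of 5 mg/kg by the intravenous route (a higher number here means a stronger effect of the compound at the dose given, a lower number a weaker effect), compound 1 gives 35% and compound 2 gives 87%. Going by the values given here, the one step between them, a number 52 percentage points higher from compound 1 to compound 2 (beyond the scatter), concerns an acetyl in place of an ethyl on an oxygen on a saturated carbon. Among the compounds with values here, compound 2 thus stands highest of the two numbers, with compound 1 its only neighbour, well beyond the scatter below it.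

Compound 3 `Cc1nc2c(OCc3ccccc3)cccn2c1COC(=O)N(C)C` has not been measured. It differs from compound 2 by dimethylamino in place of methyl on a carbonyl carbon — acetyl to dimethylcarbamoyl, read one bond further out. Within the data shown here, no measured step touches this position on the carbonyl carbon; the step from compound 1 to compound 2 concerns a different change and gives no direction here. The expectation is therefore a step no larger than the scatter, a number 12 percentage points lower from compound 2 to compound 3 (beyond the scatter), in this assay. Compound 3 is estimated at 75%, with a range from 45% to 95%.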

Compound 3, a percentage reported as inhibition, in the whole organism at one dose (the size of the read-out at that dose, not a potency): 23%
Compound 3: middle estimate off by 52 percentage points, on the high side; the measured number lies below the stated range.
By their numbers in this assay, from the lowest: compound 3; then compound 1; then compound 2.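

In this assay, the group on the carbonyl carbon decides the outcome: dimethylamino in place of methyl gives a number 64 percentage points lower from compound 2 to compound 3 (beyond the scatter) and leaves compound 3 lowest of the three, so retaining the carbonyl does not by itself retain the effect seen with acetyl. Dimethylcarbamoyl, set against ethyl, gives a number 12 percentage points lower from compound 1 to compound 3 (beyond the scatter) and so does not reproduce the gain seen with acetyl; among these three compounds, the high number goes with acetyl alone. Nothing available here accounts for this reversal.

The compounds shown leave open whether the drop is specific to dimethylamino or extends to other replacements for methyl on the carbonyl carbon. Amino, methylamino, ethyl or methoxy at that carbon would bear on that question.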